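Dropping a Bromo Group From the Core of Compound 3

This account rests on a few compounds, and the source may have more. Where it says the series, first, only, none or still open, it means among the compounds named here.

Compound 1 `CCCNc1nc(Nc2ccc(C#N)cc2)nc(Oc2ccc3cc(Br)ccc3c2Br)n1`: in an ADME assay on MT4 cells (Homo sapiens) for cytotoxicity, read by MTT assay, with a stated time of 4 days (on this read-out lower numbers stand for higher toxicity in this test and higher numbers for lower toxicity in this test), compound 1 gives 134000 nM.
Compound 2 `CCCNc1nc(Nc2ccc(C#N)cc2)nc(Oc2ccc3ccccc3c2Br)n1`: in this assay compound 2 gives only > 263000 nM, which is a limit of the assay and not a number.
Compound 3 `N#Cc1ccc(Nc2nc(N)nc(Oc3ccc4cc(Br)ccc4c3Br)n2)cc1`: in this assay compound 3 gives 244000 nM.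

Compound 4 `N#Cc1ccc(Nc2nc(N)nc(Oc3ccc4cc(Br)ccc4c3)n2)cc1` has not yet been measured. It differs from compound 3 by hydrogen in place of bromo on an aromatic carbon. The same kind of change is made from compound 1 to compound 2, (hydrogen in place of bromo on an aromatic carbon), where it produced an at least 1.9-fold higher number from compound 1 to compound 2 (0.29 log units; that floor lies within the scatter). The two places are not identical: in compound 1 the bromo sits meta and para to a fused ring, in compound 3 it sits ortho to a fused ring and ortho to a large group. The two cores differ by hydrogen in place of propyl on a nitrogen on an aromatic ring, a change that gave a 1.8-fold higher number from compound 1 to compound 3 (0.26 log units; within the scatter). From compound 3 to compound 4 a step of about a 1.3-fold higher number from compound 3 to compound 4 (0.12 log units; within the scatter) is expected, resting on compound 2 giving > 263000 nM. Compound 4 is therefore estimated at 320000 nM, in the range 180000 nM to 600000 nM.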

Compound 4, half-maximal cytotoxic concentration: 243000 nM
Estimate against measurement, compound 4: 1.3-fold (0.12 log units) above; low and high end bracket the measured number.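

In this assay, hydrogen in place of bromo gives a 1.0-fold lower number from compound 3 to compound 4 (0.00 log units; within the scatter), so on this core the swap shows no change beyond the scatter. This does not show that the change behaves alike on both cores, nor that it behaves differently: the same change on two cores in this assay, an at least 1.9-fold higher number (0.29 log units; that floor lies within the scatter) from compound 1 to compound 2 and a 1.0-fold lower number (0.00 log units; within the scatter) from compound 3 to compound 4; the limit leaves it open whether they differ. The value of compound 2 is a limit of the assay and not a number: the limit of > 263000 nM in this assay, at which 1 of the 4 values shown sits.

The compounds shown leave open how another group, such as chloro, methyl or an amine, would read at the place the bromo leaves in compound 3. They also leave open whether the swap would read the same on a core carrying a longer chain than propyl on the nitrogen.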